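The compounds below may be only part of what the source reports. "The series", "measured", "known", "first", "only" and "open" are said of these compounds alone.

Measured so far: compound 1 `COc1ccc(-c2cn(-c3ccc(O)c(C(=O)Nc4cccc(C(F)(F)F)c4)c3)nn2)cc1` with 12% in a functional assay on CCRF-CEM cells (Homo sapiens) for inhibition, read by MTT assay, with a stated time of 2 days, tested at 10 uM (a higher number here means more inhibition at the concentration tested (going by the name of the read-out), a lower number less inhibition), and compound 2 `COc1cc(OC)cc(-c2cn(-c3ccc(O)c(C(=O)Nc4cccc(C(F)(F)F)c4)c3)nn2)c1` with 73%.

Compound 1 stands lowest of the two numbers; its nearest neighbour is compound 2, reached by a number 61 percentage points higher from compound 1 to compound 2 (beyond the scatter). Compound 3 `COc1ccc(-c2cn(-c3ccc(O)c(C(=O)OCCCc4ccccc4)c3)nn2)cc1` is not yet measured. It differs from compound 1 in one place: 3-phenylpropoxy in place of (3-(trifluoromethyl)phenyl)amino on a carbonyl carbon. Among the measured compounds shown here, the only measured step exchanges 4-methoxyphenyl for 3,5-dimethoxyphenyl and does not touch the carbonyl substituent, so no measured step bears on this change and no direction is indicated beyond the scatter. Compound 3 is therefore expected to give 15%, within a range of 0% to 45%. The expected step is a number 3 percentage points higher from compound 1 to compound 3 (within the scatter).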

Compound 3, a percentage reported as inhibition, at one concentration (the size of the read-out at that concentration, not a potency): 5%
The estimate for compound 3 lay 10 percentage points above the measured number; low and high end bracket the measured number.
By their numbers in this assay, from the lowest: compounds 3 and 1 (each within the scatter of the next); then compound 2.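

In this assay, putting 3-phenylpropoxy in place of (3-(trifluoromethyl)phenyl)amino on the carbonyl carbon gives a number 7 percentage points lower from compound 1 to compound 3 (within the scatter) and so shows that this position, unchanged until now, can take the exchange without a readable shift. This holds only with the 4-methoxyphenyl group, where compound 1 already stands at 12% and little room remains for a fall to show. Nothing at hand offers a reason for this result. From the compounds shown here alone, whether 3-phenylpropoxy would behave the same with the 3,5-dimethoxyphenyl group of compound 2 stays open, as does what a carboxylic acid or a shorter chain on the carbonyl carbon would give.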